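From Methyl to tert-Butyl on a Benzyl Group

The source may hold more compounds than are shown below. What is called first, only, known or untested is meant among the compounds shown, and "the series" means these compounds.

Three hydroxamic acids share one core and differ only in the group attached to it. Compound 1 `Cc1ccccc1CN1CC=C(CCC(=O)NO)C1=O` and compound 2 `Cc1ccc(CN2CC=C(CCC(=O)NO)C2=O)cc1` carry methyl-substituted benzyl groups, while compound 3 `O=C(CCC1=CCN(CCCCc2ccc(Cl)cc2)C1=O)NO` carries a longer chain ending in a chlorophenyl ring. In a functional assay on MDA-MB-231 cells (Homo sapiens) for inhibition, read by sulforhodamine B assay (a higher number here means a weaker inhibitor of growth, a lower number a stronger inhibitor of growth), compound 1 gives 1990 nM, compound 2 gives 1990 nM and compound 3 gives 4150 nM. Compound 2 therefore stands level with compound 1, the two together at the lowest numbers of the three, while compound 3 sits higher by a gap beyond the usual scatter. Compound 4 `CC(C)(C)c1ccc(CN2CC=C(CCC(=O)NO)C2=O)cc1` differs from compound 2 by a single change: tert-butyl in place of methyl on an aromatic carbon. Among the compounds with values here, no measured pair calibrates this change, so in this assay the step is expected to be a small one of a 1.3-fold lower number from compound 2 to compound 4 (0.12 log units; within the scatter). Compound 4 is accordingly expected to give 1500 nM, within a range of 600 nM to 4000 nM.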

Compound 4, concentration for 50% growth inhibition: 690 nM
Compound 4: middle estimate off by 2.2-fold (0.34 log units), on the high side; the range from low to high includes it.
By their numbers in this assay, from the lowest: compound 4; then compounds 1 and 2 (each within the scatter of the next); then compound 3.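

Tert-butyl in place of methyl on an aromatic carbon, para to a large group, gives the only step here between compounds differing in one place, and in this assay it is a 2.9-fold lower number from compound 2 to compound 4 (0.46 log units; beyond the scatter). This position therefore takes four heavy atoms where compound 2 has one, and the number falls rather than rises. Nothing available accounts for this step. On these data alone, it remains open whether an ethyl or isopropyl group at this place would give a smaller step, and whether an amine or a carboxylic acid would keep the lower number.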